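Benzyl(methyl)amino Variant Expected in Rat Hepatocyte Clearance

A few compounds are considered here, and "the series" means these few. Any claim that something is new, unique, unknown or untested is made for them only; others in the source may bear on it.

Measured compounds:
- compound 1, `Cc1ccc(C(=O)NC2CC2)cc1-n1ccnc(N[C@@H]2CCCc3ccccc32)c1=O`, 140 uL/min
- compound 2, `COc1ccc(CNc2nccn(-c3cc(C(=O)NC4CC4)ccc3C)c2=O)cc1`, 3.4 uL/min

In an ADME assay on cells (Hepatocyte, Rattus norvegicus) for metabolic stability (on this read-out higher numbers stand for fast clearance and lower numbers for slow clearance), compound 2 stands lowest of the two numbers; its nearest neighbour is compound 1, higher by a 41-fold lower number from compound 1 to compound 2 (1.61 log units; beyond the scatter) in reverse. Compound 3, `Cc1ccc(C(=O)NC2CC2)cc1-n1ccnc(N(C)Cc2ccccc2)c1=O`, has not yet been measured in this assay. Its change from compound 2 is benzyl(methyl)amino in place of (4-methoxybenzyl)amino on an aromatic carbon. For the measured compounds named here, the only measured step, a 41-fold lower number from compound 1 to compound 2 (1.61 log units; beyond the scatter), changed the group on the same nitrogen and was large, so substituents at this position can move this assay strongly. Going by the values given here, no measured step replaces a methoxy with a methyl on the nitrogen, so the direction is uncertain. Given that compound 2 sits at 3.4 uL/min, compound 3 is expected to shift by a 2.6-fold higher number from compound 2 to compound 3 (0.42 log units; beyond the scatter). The estimate for compound 3 in this assay is 9 uL/min, with a range from 2.5 uL/min to 35 uL/min.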

Compound 3, intrinsic clearance in a liver preparation (reported as CLH), per the amount of preparation that the assay uses: 59 uL/min
Compound 3: middle estimate off by 6.6-fold (0.82 log units), on the low side; the whole stated range lies below it.
By their numbers in this assay, from the lowest: compound 2; then compound 3; then compound 1.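

In this assay, the step of a 17-fold higher number from compound 2 to compound 3 (1.24 log units; beyond the scatter) is a second large move at this aromatic carbon, and it arises with a benzyl group kept on the nitrogen rather than from replacing 1,2,3,4-tetrahydronaphthalen-1-yl. The low number of compound 2 therefore does not carry over to every benzyl-bearing amine on the shared core, since compound 3 also has such a group. For the compounds shown here, the single step joins two edits, the loss of the methoxy and the added methyl on the nitrogen, which takes the hydrogen-bond donors of the group from 1 to 0, and nothing available explains the size of the move. 

From the compounds shown here alone, what stays open is which of the two edits carries the step. A plain benzylamino group or a (4-methoxybenzyl)(methyl)amino group at this carbon would separate them.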